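Acylurea thiazole hydrazones: swapping the dichlorophenyl for difluorophenyl

The source may report more compounds than this note shows. Statements on the series, on what has been measured and on what is new or still open speak of the compounds shown alone.

In a functional assay on HeLa cells (Homo sapiens) for inhibition, read by MTT assay, with a stated time of 72 h (a lower number here means a stronger inhibitor, a higher number a weaker inhibitor), compound 3 `Cc1nc(N(C)C(=O)NC(=O)c2ccc(Cl)cc2Cl)sc1C(=O)N/N=C/c1ccc(C(F)(F)F)cc1` gives 20.3 ug/mL, the highest number among the two measured values; compound 2 `CN(C(=O)NC(=O)c1ccc(Cl)cc1Cl)c1nc(C(F)(F)F)c(C(=O)N/N=C/c2ccc(C(F)(F)F)cc2)s1` gives 7.99 ug/mL, and the step of a 2.5-fold higher number from compound 2 to compound 3 (0.40 log units; beyond the scatter) is modest. Compound 1 `CNc1nc(C)c(C(=O)N/N=C/c2ccccc2C(F)(F)F)s1` reaches only a limit, > 100 ug/mL, in this assay. Compound 4 `Cc1nc(N(C)C(=O)NC(=O)c2c(F)cccc2F)sc1C(=O)N/N=C/c1ccc(C(F)(F)F)cc1` differs from compound 3 by 2,6-difluorophenyl in place of 2,4-dichlorophenyl on a carbonyl carbon. Going by the values given here, no measured step touches this position, so the only guide is the shared scaffold of compound 3. A change beyond the scatter is therefore not predicted in this assay, though the number may drift upward; the expected step is a 1.5-fold higher number from compound 3 to compound 4 (0.17 log units; within the scatter). Compound 4 is estimated at 30 ug/mL, within 10 ug/mL to 100 ug/mL.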

Compound 4, half-maximal inhibitory concentration: 40.6 ug/mL
Compound 4: the middle estimate sits 1.4-fold (0.13 log units) below what was measured, within the range that was stated.
By their numbers in this assay, from the lowest: compound 2; then compounds 3 and 4 (each within the scatter of the next). At a limit, above all of these: compound 1.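

In this assay, going by these compounds alone, the first change at this position, 2,6-difluorophenyl in place of 2,4-dichlorophenyl on a carbonyl carbon, gives a 2.0-fold higher number from compound 3 to compound 4 (0.30 log units; within the scatter), so the two groups cannot be told apart here. No information given here accounts for this step.

On these data alone, whether plain phenyl, or a phenyl carrying an amine, on this carbonyl carbon would move the number beyond the scatter remains open. Also open, as far as these compounds go, is whether the same exchange would give a similar step with the trifluoromethyl of compound 2 in place of the methyl.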